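Cyano to fluoro: from compound 2 to compound 4

A few compounds are considered here, and "the series" means these few. Any claim that something is new, unique, unknown or untested is made for them only; others in the source may bear on it.

Measured so far in a functional assay on KB-VIN10 cells (Homo sapiens) for inhibition, with a stated time of 72 h; a higher number here means a weaker inhibitor, a lower number a stronger inhibitor
- compound 1 `COc1ccc(S(=O)(=O)N2CCc3cccc(-c4ccc(N)cc4)c32)cc1`: 262 nM
- compound 2 `COc1ccc(S(=O)(=O)n2ccc3cccc(-c4ccc(C#N)cc4)c32)cc1`: 146 nM
- compound 3 `COc1ccc(S(=O)(=O)N2CCc3cccc(-c4cccnc4)c32)cc1`: 84.5 nM

Compound 2 (146 nM) lies within the scatter of both other compounds in this assay and cannot be ranked against either.

Compound 4 `COc1ccc(S(=O)(=O)n2ccc3cccc(-c4ccc(F)cc4)c32)cc1` keeps the core of compound 2 and carries fluoro in place of cyano on an aromatic carbon, para to a large group (fluoro in place of cyano on an aromatic carbon).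

Within the data shown here, only one measured step bears on this change, and only loosely (a 3.1-fold lower number from compound 1 to compound 3 (0.49 log units; beyond the scatter)). It is a modest step that exchanges 4-aminophenyl for pyridin-3-yl on the core of compound 1, which is not the core of compound 2. Neither cyano nor fluoro takes part in it, so it gives a rough size for a change at this place but no direction. Among the measured compounds shown here, no measured pair isolates the cyano to fluoro exchange.

The expectation therefore rests on compound 2 (146 nM), with no step beyond the scatter and no direction assigned. The expected step is small (a 1.0-fold higher number from compound 2 to compound 4 (0.01 log units; within the scatter)). Compound 4 is estimated at 150 nM within an expected range of 55 nM to 420 nM.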

Compound 4, half-maximal inhibitory concentration: 202 nM
Compound 4: the middle estimate sits 1.3-fold (0.13 log units) below what was measured, within the range that was stated.
By their numbers in this assay, from the lowest: compounds 3, 2, 4 and 1 (each within the scatter of the next, the first and the last beyond it).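

In this assay, compounds 2 and 4 form the only pair shown that isolates the exchange of 4-cyanophenyl for 4-fluorophenyl on a shared core, and it reads as a 1.4-fold higher number from compound 2 to compound 4 (0.14 log units; within the scatter). At this place on the ring, then, fluoro can stand in for cyano, and the nitrile's hydrogen-bond acceptor can go, without a step that can be told from the scatter. No measured property is available that would explain this result.

Still open, going by these compounds, is whether a group of another kind at this place on the shared core, such as a carboxylic acid or a longer alkyl chain, would give a step beyond the scatter. Also open, on these data alone, is whether the exchange of 4-aminophenyl for pyridin-3-yl, seen on the core of compound 1 as a 3.1-fold lower number from compound 1 to compound 3 (0.49 log units; beyond the scatter), would give a step of similar size on the core shared by compound 2 and compound 4.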